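Swapping a trifluoromethylphenyl for pyridinyl in a Bcl-2 series

A few compounds are considered here, and "the series" means these few. Any claim that something is new, unique, unknown or untested is made for them only; others in the source may bear on it.

Measured compounds:
compound 1: `CN(C)CC[C@H](CSc1ccccc1)Nc1ccc(S(=O)(=O)NC(=O)c2ccc(N3CCC(=Cc4ccccc4Cl)CC3)cc2)cc1[N+](=O)[O-]`, 450 nM
compound 2: `CN(C)CC[C@H](CSc1ccccc1)Nc1ccc(S(=O)(=O)NC(=O)c2ccc(N3CCC(=Cc4ccccc4C(F)(F)F)CC3)cc2)cc1[N+](=O)[O-]`, 210 nM
compound 3: `CN(C)CC[C@H](CSc1ccccc1)Nc1ccc(S(=O)(=O)NC(=O)c2ccc(N3CCC(=Cc4ccccn4)CC3)cc2)cc1[N+](=O)[O-]`, not yet measured

Both measured compounds share one core and differ only in the aromatic ring that hangs from the double-bonded chain carbon. In a functional assay (FL5.12 cells, Mus musculus) with Apoptosis regulator Bcl-2 (Homo sapiens) as the target (a higher number here means that more compound is needed for the effect, a lower number that less compound is needed), compound 1 gives 450 nM and compound 2 gives 210 nM. Within the data shown here, the only comparison is a 2.1-fold lower number from compound 1 to compound 2 (0.33 log units; beyond the scatter), which leaves compound 2 with the lowest of the two numbers and compound 1 as its nearest neighbour.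

Compound 3 carries the change (pyridin-2-yl in place of 2-(trifluoromethyl)phenyl on a double-bonded chain carbon bound to a double-bonded ring carbon). Among the measured compounds shown here, no measured step covers the exchange of a carbon-only ring for one holding a nitrogen, nor the loss of the ring substituent altogether. For the measured compounds named here, the one step that bears on it, a 2.1-fold lower number from compound 1 to compound 2 (0.33 log units; beyond the scatter), shows that the substituent on this ring moves the number modestly, and compound 3 gives that substituent up. A rise back toward compound 1, possibly beyond it, is therefore expected; the expected step is a 2.1-fold higher number from compound 2 to compound 3 (0.33 log units; beyond the scatter). For compound 3 the estimate is 450 nM, with a range from 180 nM to 1200 nM.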

Compound 3, half-maximal effective concentration: 1380 nM
Estimate against measurement, compound 3: 3.1-fold (0.49 log units) below; the whole stated range lies below it.
By their numbers in this assay, from the lowest: compound 2; then compound 1; then compound 3.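

In this assay, the position on a double-bonded chain carbon bound to a double-bonded ring carbon proves more sensitive than the first pair alone could show. Exchanging 2-(trifluoromethyl)phenyl for pyridin-2-yl brings a 6.6-fold higher number from compound 2 to compound 3 (0.82 log units; beyond the scatter), a wider step than the single one known earlier, and exchanging 2-chlorophenyl for pyridin-2-yl still brings a 3.1-fold higher number from compound 1 to compound 3 (0.49 log units; beyond the scatter). Both rings of carbon only, each with its substituent, therefore give lower numbers than pyridin-2-yl, and the three rings now fall into an order in which every step lies beyond the scatter.

Pyridin-2-yl differs from the other two rings in two ways at once, as it holds a ring nitrogen and lacks a substituent, and the compounds shown cannot tell these two changes apart. From the compounds shown here alone, an unsubstituted phenyl ring, or a pyridin-2-yl ring carrying a trifluoromethyl group, would separate them, and whether the ring nitrogen or the lost substituent weighs more remains open.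

Nothing at hand offers an explanation for the rise in the number with this exchange.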